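Removing the Bromo from Compound 2

The source may hold more compounds than are shown below. What is called first, only, known or untested is meant among the compounds shown, and "the series" means these compounds.

Compound 1 `CCCSc1nc(N/N=C(\C)c2ccccc2O)c2nnn(Cc3ccccc3)c2n1`: 11100 nM
Compound 2 `CCCSc1nc(N/N=C/c2ccc(Br)cc2)c2nnn(Cc3ccccc3)c2n1`: > 64000 nM

Both compounds were measured in a functional assay on ECa-109 cells (Homo sapiens) for antiproliferative activity, read by MTT assay, with a stated time of 72 h; a lower number here means a stronger inhibitor, a higher number a weaker inhibitor. Compound 2 stands at > 64000 nM, which is a limit and not a number. Compound 1, by contrast, has a measured number, so it is the only firm reference point here.

Compound 3 `CCCSc1nc(N/N=C/c2ccccc2)c2nnn(Cc3ccccc3)c2n1` comes from compound 2 by a single change: hydrogen in place of bromo on an aromatic carbon. In words, this is hydrogen in place of bromo on an aromatic carbon, para to a large group.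

Within the data shown here, one measured step bears on this change: an at least 5.7-fold higher number from compound 1 to compound 2 (0.76 log units; beyond the scatter). Among the measured compounds shown here, that step replaces the whole group on a nitrogen on an aromatic ring, not the bromo alone, and no measured pair isolates the bromo. It is therefore only a loose guide to compound 3. A small move towards a lower number is expected, perhaps none beyond the scatter, and another reading at the limit would fit as well. The expected result is an at least 1.6-fold lower number from compound 2 to compound 3 (0.22 log units; that floor lies within the scatter). The estimate for compound 3 is 38000 nM, with an expected range from 12000 nM to 90000 nM.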

Compound 3, half-maximal inhibitory concentration: > 64000 nM
Compound 3 gave a limit, no number; the forecaster's own chance of this, stated with the estimate: 40%; at least 1.6-fold (0.22 log units) between middle value and limit.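

In this assay, taking the bromo away gives no readable gain: the step from 4-bromophenyl to phenyl cannot be read, because compound 2 and compound 3 both sit at a limit and neither has a number: the limit of > 64000 nM in this assay, at which 2 of the 3 values shown sit.

The earlier compounds shown here left open whether the bromo alone held compound 2 at that limit, and compound 3 shows that it does not, since a plain phenyl reaches a limit too. Among these compounds, the distance from the one measured compound also persists without the bromo, with an at least 5.7-fold higher number from compound 1 to compound 3 (0.76 log units; beyond the scatter), much as it stood with the bromo in place, with an at least 5.7-fold higher number from compound 1 to compound 2 (0.76 log units; beyond the scatter).

Compound 1 still differs from compound 3 in a whole group, which carries both a hydroxyl and a methyl, so the compounds shown do not tell which of these, if either, goes with the measurable activity of compound 1. They also leave open whether any other group at this place on the ring, such as an amine or a carboxylic acid in place of the bromo, would bring a compound back from the limit to a measurable number.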